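The source may report more compounds than this note shows. Statements on the series, on what has been measured and on what is new or still open speak of the compounds shown alone.

Compound 1 `COc1ccc(C(=O)/C=C/c2cn(-c3ccccc3)nc2-c2cccnc2)cc1OC` carries a 3,4-dimethoxyphenyl group on its carbonyl carbon and a pyridin-3-yl group on the shared core. In a functional assay on MCF7 cells (Homo sapiens) for inhibition, read by sulforhodamine B assay, with a stated time of 72 h (on this read-out lower numbers stand for stronger inhibition and higher numbers for weaker inhibition), compound 1 gives 1700 nM. Compound 2 `COc1ccc(OC)c(C(=O)/C=C/c2cn(-c3ccccc3)nc2-c2cccnc2)c1` differs from it by 2,5-dimethoxyphenyl in place of 3,4-dimethoxyphenyl on a carbonyl carbon, and in this assay compound 2 gives 1500 nM, so a 1.1-fold lower number from compound 1 to compound 2 (0.05 log units; within the scatter). Compound 3 `COc1ccc(C(=O)/C=C/c2cn(-c3ccccc3)nc2-c2ccncc2)cc1OC` differs from compound 1 by pyridin-4-yl in place of pyridin-3-yl on an aromatic carbon, and in this assay compound 3 gives 4300 nM, so a 2.5-fold higher number from compound 1 to compound 3 (0.40 log units; beyond the scatter). Compound 4 `COc1ccc(OC)c(C(=O)/C=C/c2cn(-c3ccccc3)nc2-c2ccncc2)c1` is not yet measured; it differs from compound 3 by 2,5-dimethoxyphenyl in place of 3,4-dimethoxyphenyl on a carbonyl carbon, the same change seen from compound 1 to compound 2. Because a 1.1-fold lower number from compound 1 to compound 2 (0.05 log units; within the scatter) stayed within the scatter, a step of similar size, a 1.1-fold lower number from compound 3 to compound 4 (0.03 log units; within the scatter), is expected here. Compound 4 is therefore estimated at 4000 nM, most likely between 2000 nM and 8000 nM.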

Compound 4, half-maximal inhibitory concentration: 1400 nM
Compound 4: the middle estimate sits 2.9-fold (0.46 log units) above what was measured; measured number outside the range, below it.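

In this assay, the swap to 2,5-dimethoxyphenyl gives a 3.1-fold lower number from compound 3 to compound 4 (0.49 log units; beyond the scatter), although the same swap made no clear difference when the compound carried pyridin-3-yl, so the two readings disagree: the same change on two cores in this assay, a 1.1-fold lower number (0.05 log units; within the scatter) from compound 1 to compound 2 and a 3.1-fold lower number (0.49 log units; beyond the scatter) from compound 3 to compound 4, 2.7-fold (0.43 log units) apart, beyond the scatter of two such steps. Likewise, the change to pyridin-4-yl gives a 1.1-fold lower number from compound 2 to compound 4 (0.03 log units; within the scatter), which does not match its effect in the 3,4-dimethoxyphenyl compounds: the same change on two cores in this assay, a 2.5-fold higher number (0.40 log units; beyond the scatter) from compound 1 to compound 3 and a 1.1-fold lower number (0.03 log units; within the scatter) from compound 2 to compound 4, 2.7-fold (0.43 log units) apart, beyond the scatter of two such steps. Across these four compounds, the effect of each change depends on the other group present, so neither step carries over reliably, but the data do not show why this happens or whether it extends to other groups.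

Going by these compounds, it remains open how a pyridin-2-yl group on that aromatic carbon would behave. The same applies to a single methoxy group on the phenyl ring attached to the carbonyl carbon.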